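Changing one aryl group on a carbonyl carbon

This account rests on a few compounds, and the source may have more. Where it says the series, first, only, none or still open, it means among the compounds named here.

- compound 1 `Cc1cc(C)cc(C(=O)N(CCCCCC(=O)Nc2ccccc2N)CC(=O)NC2CCCCC2)c1` with 17500 nM
- compound 2 `Cc1cc(C)cc(C(=O)N(CC(=O)NCc2ccccc2)Cc2ccc(C(=O)Nc3cc(-c4ccccc4)ccc3N)cc2)c1` with 8900 nM

Among the compounds with values here, both numbers come from a functional assay on CAL-27 cells (Homo sapiens) for cytotoxicity, read by MTT assay, with a stated time of 72 h (a higher number here means a weaker inhibitor, a lower number a stronger inhibitor), and are the only measurements available. Compound 2 gives 8900 nM and compound 1 gives 17500 nM and these two values lie within the usual scatter of each other, so neither compound can be ranked above the other.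

Compound 3 `CN(C)c1ccc(C(=O)N(CC(=O)NCc2ccccc2)Cc2ccc(C(=O)Nc3cc(-c4ccccc4)ccc3N)cc2)cc1` keeps everything in compound 2 except one group, with 4-(dimethylamino)phenyl in place of 3,5-dimethylphenyl on a carbonyl carbon. Within the data shown here, no measured pair of compounds shows this change or any other single change, so the data offer no precedent for its size.

In this assay the expectation is therefore a small shift at most, none beyond the scatter, with only a slight lean towards a lower number. The estimated move is a 1.3-fold lower number from compound 2 to compound 3 (0.10 log units; within the scatter) and it rests on compound 2 at 8900 nM as the sole anchor. Compound 3 is expected at 7000 nM within an estimated range from 2500 nM to 20000 nM as a number rather than a limit.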

Compound 3, half-maximal inhibitory concentration: 11100 nM
The estimate for compound 3 lay 1.6-fold (0.20 log units) below the measured number; low and high end bracket the measured number.
By their numbers in this assay, from the lowest: compounds 2, 3 and 1 (each within the scatter of the next).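

In this assay, within the data shown here, the exchange of 3,5-dimethylphenyl for 4-(dimethylamino)phenyl on a carbonyl carbon whose other neighbour is the amide-type nitrogen is the first single-place comparison available here, and it reads as a 1.2-fold higher number from compound 2 to compound 3 (0.10 log units; within the scatter). This position therefore accepts a ring bearing a nitrogen-containing group and a hydrogen-bond acceptor, in place of one bearing two methyl groups, with no difference that can be told from the scatter, so compound 2 and compound 3 cannot be ranked. Nothing available explains this outcome or ties it to any feature of either group.

What the compounds shown leave open is whether this tolerance reaches beyond these two aryl groups, since a single pair cannot show how other groups at this position would read, such as a ring carrying a carboxylic acid, a ring carrying a morpholine, or a plain methyl group in place of the aryl ring. They also leave open whether the same exchange would read alike on a different core, as the comparison rests on one background only.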